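From pyridinyl to carboxyphenyl on the shared core

This account rests on a few compounds, and the source may have more. Where it says the series, first, only, none or still open, it means among the compounds named here.

Two measured compounds share a core and differ only in the aromatic group attached to one carbon of the five-membered aromatic ring with four nitrogens. Compound 1 `CCCCCCCCc1ccc(OCC(=O)Cn2nnc(-c3cccc(Cl)c3)n2)cc1` carries a 3-chlorophenyl there, and in an assay on microsomes from brain for inhibition of Fatty-acid amide hydrolase 1 (Rattus norvegicus), read by fluorescence and HPLC, with a stated time of 60 min (a higher number here means a weaker inhibitor, a lower number a stronger inhibitor), compound 1 gives 24 nM. Compound 2 `CCCCCCCCc1ccc(OCC(=O)Cn2nnc(-c3ccncc3)n2)cc1` carries a pyridin-4-yl in its place, and in this assay compound 2 gives 24 nM. The step of no change at the digits printed from compound 1 to compound 2 (within the scatter) shows that this swap made no difference beyond the scatter, so compound 2 stands level with compound 1 at the digits shown.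

Compound 3 `CCCCCCCCc1ccc(OCC(=O)Cn2nnc(-c3cccc(C(=O)O)c3)n2)cc1` has not been measured. Relative to compound 2 the change is 3-carboxyphenyl in place of pyridin-4-yl on an aromatic carbon. Going by the values given here, only the step from compound 1 to compound 2 bears on this position, and it was flat within the scatter; there is no measured example of a carboxyl-bearing group at this place. On that basis the expected step from compound 2 to compound 3 is small, a 1.3-fold higher number from compound 2 to compound 3 (0.10 log units; within the scatter), and compound 3 in this assay is estimated at 30 nM, with a range from 10 nM to 100 nM.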

Compound 3, half-maximal inhibitory concentration: 36 nM
Compound 3: middle estimate off by 1.2-fold (0.08 log units), on the low side, within the range that was stated.
By their numbers in this assay, from the lowest: compounds 1, 2 and 3 (each within the scatter of the next).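

In this assay, going by these compounds alone, the earlier compounds held no carboxyl-bearing group at this place, and 3-carboxyphenyl in place of pyridin-4-yl gives a 1.5-fold higher number from compound 2 to compound 3 (0.18 log units; within the scatter). Carboxy in place of chloro on an aromatic carbon gives a 1.5-fold higher number from compound 1 to compound 3 (0.18 log units; within the scatter), so the flat result now extends across all three aromatic groups shown, including one that brings a hydrogen-bond donor and more heavy atoms than pyridin-4-yl. No independent measurement is available that would explain why these three groups cannot be separated in this assay.

On these data alone, it remains open whether this level would hold for an aminophenyl, for the methyl ester of the carboxylic acid, or for a cyclohexyl group on the same aromatic carbon. As far as these compounds go, it is also open whether 3-carboxyphenyl would still read level with pyridin-4-yl and 3-chlorophenyl if the octyl chain on the shared core were replaced by a shorter chain, since all three compounds carry that same chain.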